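This account rests on a few compounds, and the source may have more. Where it says the series, first, only, none or still open, it means among the compounds named here.

Compound 1 `CC(=O)c1cc(-c2ccc(F)cc2)cc2cc(-c3ccccc3)[nH]c12`: 82.7%
Compound 2 `COc1ccc(-c2cc(C(C)=O)c3[nH]c(-c4ccccc4)cc3c2)cc1`: 73.1%

In a functional assay on HeLa cells (Homo sapiens) for cytotoxicity, read by MTT assay, with a stated time of 2 days, tested at 1 uM (a lower number here means a stronger effect, a higher number a weaker effect of the compound at the concentration tested), compound 2 gives 73.1%. Among the measured compounds shown here, the only measured step, a number 9.6 percentage points lower from compound 1 to compound 2 (within the scatter), lies within the scatter, so the two numbers stand together. Compound 3 `COc1ccc(-c2cc(C(C)=O)c3[nH]c(-c4ccc(OC)cc4)cc3c2)cc1` differs from compound 2 by methoxy in place of hydrogen on an aromatic carbon. For the measured compounds named here, no measured step tests this change; the step from compound 1 to compound 2 concerns methoxy in place of fluoro, not hydrogen, and was itself within the scatter. Nothing therefore points to a shift beyond the scatter in this assay. Compound 3 is expected to give 73%, between 58% and 88%. The estimated step is a number 0.1 percentage points lower from compound 2 to compound 3 (within the scatter).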

Compound 3, a percentage reported as activity, at one concentration (the size of the read-out at that concentration, not a potency): 60.2%
Estimate against measurement, compound 3: 12.8 percentage points above, and the stated range covers the measured number.
By their numbers in this assay, from the lowest: compound 3; then compounds 2 and 1 (each within the scatter of the next).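

In this assay, among the compounds shown here, the change from phenyl to 4-methoxyphenyl gives (a number 12.9 percentage points lower from compound 2 to compound 3 (beyond the scatter)), the first step here beyond the scatter. For the compounds shown here, the only earlier step (a number 9.6 percentage points lower from compound 1 to compound 2 (within the scatter)) placed methoxy at a different position in place of fluoro and stayed within the scatter, so this result first ties a lower number to methoxy on an aromatic carbon para to a large group. No evidence is available to explain this shift.

The compounds shown leave open whether an amine or a carboxylic acid at this position would lower the number as methoxy does. They also leave open whether a longer chain, such as ethoxy, would lower it further.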